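Replacing the isopropylpiperazinylmethyl group on compound 2

The source may report more compounds than this note shows. Statements on the series, on what has been measured and on what is new or still open speak of the compounds shown alone.

Measured compounds:
- compound 1, `c1ccc2c(c1)CN[C@@H](CN(CC[C@H]1CCCNC1)[C@H]1CCCc3cccnc31)C2`: 55%
- compound 2, `CC(C)N1CCN(CCCN(C[C@H]2Cc3ccccc3CN2)[C@H]2CCCc3cccnc32)CC1`: 4%
- compound 3, `c1cnc2c(c1)CCC[C@@H]2N(CCCN1CCNCC1)Cc1cc2ccccc2cn1`: 59%

In an ADME assay on microsomes from liver (Rattus norvegicus) for metabolic stability, read by LC-MS, with a stated time of 10 min, tested at 0.5 uM (a higher number here means that more of the compound is left, a lower number that less of the compound is left), compound 2 gives the lowest of the three numbers. Going by the values given here, compound 1 stands a number 51 percentage points lower from compound 1 to compound 2 (beyond the scatter) apart from it, a step that is beyond the scatter, and compound 3, for which no single-point step is recorded, sits even further above compound 2 on the numbers alone.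

The next compound, compound 4, `c1ccc2c(c1)CN[C@@H](CN(CCN1CCNCC1)[C@H]1CCCc3cccnc31)C2`, differs from compound 2 by piperazin-1-yl in place of (4-isopropylpiperazin-1-yl)methyl on a saturated chain carbon, two bonds along the chain from an amine nitrogen. Among the compounds with values here, only one measured step bears on this change: the step from compound 1 to compound 2, in which a saturated ring bearing a ring hydrogen on nitrogen was exchanged for the isopropyl-bearing piperazinylmethyl group, and this assay fell by a number 51 percentage points lower from compound 1 to compound 2 (beyond the scatter). The move to compound 4 undoes that kind of exchange, returning to a ring with a hydrogen-bond donor, much as in compound 1 and compound 3, both of which sit well above compound 2.

It is therefore expected that compound 4 rises by a number 46 percentage points higher from compound 2 to compound 4 (beyond the scatter) in this assay, a large step upward. Compound 4 is estimated at 50%, with a range from 30% to 70%.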

Compound 4, percent of the compound remaining: 62%
Compound 4: the middle estimate sits 12 percentage points below what was measured; the measured number falls inside the stated range.
By their numbers in this assay, from the lowest: compound 2; then compounds 1, 3 and 4 (each within the scatter of the next).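

In this assay, piperazin-1-yl in place of (4-isopropylpiperazin-1-yl)methyl gives a number 58 percentage points higher from compound 2 to compound 4 (beyond the scatter) on this saturated chain carbon, so a second group at this position now stands far above compound 2. Piperazin-1-yl in place of piperidin-3-yl gives a number 7 percentage points higher from compound 1 to compound 4 (within the scatter) and thus no difference that can be read between these two groups. Among the three groups compared at this position, only the (4-isopropylpiperazin-1-yl)methyl group of compound 2 goes with a low number, which the single step from compound 1 could not show.

The change to compound 4 takes away the isopropyl group and the methyl link together, going from 10 heavy atoms to 6, so the compounds shown do not separate the part each plays in the rise. A 4-methylpiperazin-1-yl group or a 4-isopropylpiperazin-1-yl group at the same place would bear on that question, and a morpholin-4-yl group would test whether the second ring nitrogen matters. Nothing in the material at hand explains why the number changes at this position.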